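The source may hold more compounds than are shown below. What is called first, only, known or untested is meant among the compounds shown, and "the series" means these compounds.

Series notes. Compound 1 `CC(C)C[C@H](N)c1cc(C(F)(F)F)ccc1N1CCN(C(=O)CCc2cccc(C(F)(F)F)c2)CC1` gives 2200 nM in an assay on HEK293 cells for displacement of a labelled ligand from Melanocortin receptor 4 (Homo sapiens); on this read-out lower numbers stand for stronger inhibition and higher numbers for weaker inhibition. Compound 2 `COc1cccc(CCC(=O)N2CCN(c3ccc(C(F)(F)F)cc3[C@@H](N)CC(C)C)CC2)c1` gives 4000 nM in this assay, and compound 3 `CC(C)C[C@H](N)c1cc(C(F)(F)F)ccc1N1CCN(C(=O)CCc2ccc(S(C)(=O)=O)cc2)CC1` gives 4900 nM in this assay. Compound 3 thus carries the highest of the three numbers; its gap to compound 2 stays within the scatter, whereas the step of a 2.2-fold higher number from compound 1 to compound 3 (0.35 log units; beyond the scatter) lies beyond it.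

Compound 4 `CC(C)C[C@H](N)c1cc(C(F)(F)F)ccc1N1CCN(C(=O)CCc2c(Cl)cccc2Cl)CC1` differs from compound 3 by 2,6-dichlorophenyl in place of 4-(methylsulfonyl)phenyl on a saturated chain carbon, two bonds along the chain from a carbonyl carbon. Within the data shown here, two measured steps touch the same position: a 2.2-fold higher number from compound 1 to compound 3 (0.35 log units; beyond the scatter) and a 1.2-fold higher number from compound 2 to compound 3 (0.09 log units; within the scatter). Read in reverse, both show that exchanging the 4-(methylsulfonyl)phenyl end group for another aryl gave an equal or lower number, the larger change when the incoming group carried trifluoromethyl rather than methoxy. Compound 4 brings in a group with no hydrogen-bond acceptors, as in compound 1. A modest step toward lower numbers in this assay is therefore expected, roughly the size of a 2.2-fold higher number from compound 1 to compound 3 (0.35 log units; beyond the scatter) reversed, giving an expected step of a 2.0-fold lower number from compound 3 to compound 4 (0.29 log units; within the scatter). Compound 4 is estimated at 2500 nM, with a range from 1000 nM to 6000 nM.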

Compound 4, inhibition constant: 2600 nM
The estimate for compound 4 lay 1.0-fold (0.02 log units) below the measured number; the measured number falls inside the stated range.
By their numbers in this assay, from the lowest: compounds 1, 4, 2 and 3 (each within the scatter of the next, the first and the last beyond it).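

In this assay the 2,6-dichlorophenyl end group cannot be separated from any of the three earlier aryl end groups: all three steps stay within the scatter (a 1.9-fold lower number from compound 3 to compound 4 (0.28 log units; within the scatter); a 1.5-fold lower number from compound 2 to compound 4 (0.19 log units; within the scatter); a 1.2-fold higher number from compound 1 to compound 4 (0.07 log units; within the scatter)). The earlier compounds shown here each carried one substituent on this aryl ring, whereas compound 4 shows that a ring with two chlorines also stays within the scatter of all three. Among these compounds, compound 1 and compound 3 remain the only pair separated beyond the scatter, and no evidence bears on why this position responds so little.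

Still open, on these data alone, is whether an amine or a carboxylic acid on this aryl ring would move the number beyond the scatter. A longer chain between the carbonyl and the aryl ring also remains untested in the compounds shown here.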